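The compounds below may be only part of what the source reports. "The series", "measured", "known", "first", "only" and "open" are said of these compounds alone.

In an ADME assay (liver, Mus musculus) for metabolic stability, using microsomes (on this read-out higher numbers stand for a longer-lived compound and lower numbers for a shorter-lived compound), compound 3 (`C=CC(=O)Nc1cccc(CNc2nc(Nc3cnn(C4CCN(C(C)=O)CC4)c3)ncc2Cl)c1`) gives 0.05 h, a number within the scatter of both compound 1 (`C=CC(=O)Nc1cccc(CNc2nc(Nc3cnoc3)ncc2Cl)c1`) at 0.0583 h and compound 2 (`C=CC(=O)Nc1cccc(CNc2nc(Nc3cnn(C4CCOCC4)c3)ncc2Cl)c1`) at 0.025 h. Compound 4 (`C=CC(=O)Nc1cccc(CNc2nc(Nc3cnn(CCOC)c3)ncc2Cl)c1`) carries 2-methoxyethyl in place of 1-acetylpiperidin-4-yl on an aromatic nitrogen. Going by the values given here, only one measured step bears on this place: a 2.0-fold higher number from compound 2 to compound 3 (0.30 log units; within the scatter), an exchange of oxan-4-yl for 1-acetylpiperidin-4-yl. Among the compounds with values here, no measured compound carries a group without a ring there, so the new change is untested. Given that single small step, no shift beyond the scatter is expected in this assay. The expected step is a 1.3-fold lower number from compound 3 to compound 4 (0.10 log units; within the scatter). For compound 4 the estimated half-life is 0.04 h, with an expected range of 0.018 h to 0.09 h.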

Compound 4, half-life: 0.055 h
The estimate for compound 4 lay 1.4-fold (0.14 log units) below the measured number, within the range that was stated.
By their numbers in this assay, from the lowest: compounds 2, 3, 4 and 1 (each within the scatter of the next, the first and the last beyond it).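

In this assay, going by these compounds alone, the open chain 2-methoxyethyl, the first group without a ring on this aromatic nitrogen, gives a 1.1-fold higher number from compound 3 to compound 4 (0.04 log units; within the scatter) against 1-acetylpiperidin-4-yl, so the six-membered ring is not needed to hold the half-life. Against oxan-4-yl it gives a 2.2-fold higher number from compound 2 to compound 4 (0.34 log units; beyond the scatter) and so a modest step beyond the scatter, while 1-(2-methoxyethyl)-1H-pyrazol-4-yl in place of 1,2-oxazol-4-yl gives a 1.1-fold lower number from compound 1 to compound 4 (0.03 log units; within the scatter) and leaves the half-life where it was. Nothing available explains these steps. From the compounds shown here alone, whether a longer chain, or an amine at the end of the chain in place of the methoxy group, would shift the half-life stays open.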